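Stretching the ester on compound 3 from acetyl to senecioyl

The source may report more compounds than this note shows. Statements on the series, on what has been measured and on what is new or still open speak of the compounds shown alone.

Of the compounds shown here, three share a quinone core and have been measured in a functional assay on HepG2 cells (Homo sapiens) for cytotoxicity, read by MTT assay, with a stated time of 48 h; on this read-out lower numbers stand for stronger inhibition and higher numbers for weaker inhibition. Compound 1 `CC(C)=CC[C@H](OC(=O)C=C(C)C)C1=CC(=O)c2c(O)ccc(O)c2C1=O` gives 1000 nM. Compound 2 `COc1ccc(O)c2c1C(=O)C=C(CCC=C(C)C)C2=O` gives 7640 nM. Compound 3 `COc1ccc(O)c2c1C(=O)C=C([C@H](CC=C(C)C)OC(C)=O)C2=O` gives 870 nM, the lowest of the three numbers, though its gap to compound 1 lies within the scatter; only the gap to compound 2 is beyond it, as the step of an 8.8-fold lower number from compound 2 to compound 3 (0.94 log units; beyond the scatter) shows, where acetoxy replaced hydrogen on the saturated chain carbon.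

Compound 4 `COc1ccc(O)c2c1C(=O)C=C([C@H](CC=C(C)C)OC(=O)C=C(C)C)C2=O` is not yet measured. It differs from compound 3 in one place: 2-methylprop-1-en-1-yl in place of methyl on a carbonyl carbon. Within the data shown here, no measured pair tests this change directly. Among the measured compounds shown here, the only measured step, an 8.8-fold lower number from compound 2 to compound 3 (0.94 log units; beyond the scatter), concerns putting the ester on at all, not lengthening its acyl part, so it gives no guide to the size of this step. Compound 1 carries the same (2-methylprop-1-en-1-yl)carbonyl ester on a different core and gives a number within the scatter of compound 3, which hints that the change is not large. The expected step of a 1.0-fold higher number from compound 3 to compound 4 (0.01 log units; within the scatter) is therefore small, with no clear direction beyond the scatter. Compound 4 is estimated at 900 nM, within a range of 400 nM to 2000 nM.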

Compound 4, half-maximal inhibitory concentration: 970 nM
For compound 4 the middle estimate is 1.1-fold (0.03 log units) below the measured one; the range from low to high includes it.
By their numbers in this assay, from the lowest: compounds 3, 4 and 1 (each within the scatter of the next); then compound 2.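

In this assay, swapping methyl for 2-methylprop-1-en-1-yl on the carbonyl carbon leaves the number within the scatter (a 1.1-fold higher number from compound 3 to compound 4 (0.05 log units; within the scatter)), so on this core the ester position accepts the larger acyl group with no visible change. The drop seen on adding an ester to compound 2 also holds with this second ester (a 7.9-fold lower number from compound 2 to compound 4 (0.90 log units; beyond the scatter)), beyond the scatter just as the acetoxy step was (an 8.8-fold lower number from compound 2 to compound 3 (0.94 log units; beyond the scatter)), so this drop is not confined to acetyl. Among these compounds, with the senecioyl-type ester in place on both compounds, methyl in place of hydrogen on an oxygen on an aromatic ring also stays within the scatter (a 1.0-fold lower number from compound 1 to compound 4 (0.01 log units; within the scatter)), giving the first direct reading of that core difference.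

Nothing available explains why these steps are so small or why either ester lowers the number relative to compound 2. On these data alone, what a plain hydroxy group on the same saturated chain carbon would do remains open, as does the effect of an amine, a carboxylic acid or a longer chain on the carbonyl carbon.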